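Amide aryl exchange on the shared core

The compounds below may be only part of what the source reports. "The series", "measured", "known", "first", "only" and "open" are said of these compounds alone.

In a functional assay on HepG2 cells (Homo sapiens) for cytotoxicity, read by MTT assay, with a stated time of 72 h (on this read-out higher numbers stand for weaker inhibition and lower numbers for stronger inhibition), compound 1 `CCc1ccc(C(=O)NC[C@H]2c3[nH]c4ccccc4c3C[C@H]3[C@H]4c5[nH]c6ccccc6c5C[C@@H]([C@H](C#N)N23)N4C)cc1` gives 570 nM. Among the compounds with values here, compound 2 `CN1[C@@H]2c3[nH]c4ccccc4c3C[C@H]1[C@H](C#N)N1[C@@H](CNC(=O)c3ccc4ccccc4c3)c3[nH]c4ccccc4c3C[C@@H]21` gives 1210 nM, the higher of the two numbers measured so far. Within the data shown here, the single measured step, a 2.1-fold higher number from compound 1 to compound 2 (0.33 log units; beyond the scatter), is a modest change on the same carbonyl carbon. Compound 3 `CN1[C@@H]2c3[nH]c4ccccc4c3C[C@H]1[C@H](C#N)N1[C@@H](CNC(=O)c3cc4ccccc4s3)c3[nH]c4ccccc4c3C[C@@H]21` differs from compound 2 by 1-benzothiophen-2-yl in place of naphthalen-2-yl on a carbonyl carbon. Among the measured compounds shown here, no measured step covers this exchange directly, and the one step recorded was modest. For compound 3 the expected step is a 1.1-fold lower number from compound 2 to compound 3 (0.04 log units; within the scatter), not beyond the scatter, giving an estimate of 1100 nM with a range of 450 nM to 2700 nM.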

Compound 3, half-maximal inhibitory concentration: 300 nM
Estimate against measurement, compound 3: 3.7-fold (0.56 log units) above; measured number below the stated range.
By their numbers in this assay, from the lowest: compounds 3 and 1 (each within the scatter of the next); then compound 2.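

In this assay this position on the carbonyl carbon separates two aryl groups that each carry two aromatic rings, with a 4.0-fold lower number from compound 2 to compound 3 (0.61 log units; beyond the scatter) on going from naphthalen-2-yl to 1-benzothiophen-2-yl. Set against 4-ethylphenyl, the same group gives a 1.9-fold lower number from compound 1 to compound 3 (0.28 log units; within the scatter) so compound 1 and compound 3 cannot be ordered, and the weaker reading of compound 2 stays with naphthalen-2-yl alone. Nothing at hand accounts for the difference between these groups.

On these data alone, whether the sulfur itself counts remains open, and 1-benzofuran-2-yl, with oxygen in its place, would address that. As far as these compounds go, how an amine or a carboxylic acid on the aryl group would read is also open.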